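The source may report more compounds than this note shows. Statements on the series, on what has been measured and on what is new or still open speak of the compounds shown alone.

Measured compounds:

Compound 1, `C[C@H](NC(=O)CN(c1nc(Cl)nc2[nH]cnc12)C1CC1)C(=O)OCc1ccccc1` — in a functional assay on the whole organism (Tail, strain ICR) with Mus musculus as the target, in the tail flick test, with a stated time of 30 min, at a dose of 25 umol/kg by the oral route (on this read-out higher numbers stand for a stronger effect at the one dose given and lower numbers for a weaker effect), compound 1 gives 41.2%.
Compound 2, `O=C(CN(c1nc(Cl)nc2[nH]cnc12)C1CC1)N[C@@H](CC(=O)OCc1ccccc1)C(=O)OCc1ccccc1` — in this assay compound 2 gives 34.7%.
Compound 3, `O=C(CN(c1ncnc2c1ncn2C1CCCCO1)C1CC1)N[C@@H](CC(=O)OCc1ccccc1)C(=O)OCc1ccccc1` — in this assay compound 3 gives 31.8%.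

Compound 2 and compound 1 share one core and differ in a single place: hydrogen in place of benzyloxycarbonyl on a saturated chain carbon, two bonds along the chain from an amide-type nitrogen and a carbonyl carbon. That change made a step of a number 6.5 percentage points higher from compound 2 to compound 1 (within the scatter), so the two values sit within the scatter of each other and cannot be told apart. Compound 3 carries a different core from compound 2; how the two cores differ is not broken down here, and the values of compound 2 and compound 3 also lie within the scatter of each other.

Compound 4, `C[C@H](NC(=O)CN(c1ncnc2c1ncn2C1CCCCO1)C1CC1)C(=O)OCc1ccccc1`, has not yet been measured in this assay. It stands to compound 3 exactly as compound 1 stands to compound 2: hydrogen in place of benzyloxycarbonyl on a saturated chain carbon, two bonds along the chain from an amide-type nitrogen and a carbonyl carbon. The place of the change is the same word for word in both pairs, so this is the same change made on the other core. Going by the values given here, only one measured instance of it exists, and that step was small. Compound 4 is therefore expected to give a value close to that of compound 3, with an expected step of a number 6.2 percentage points higher from compound 3 to compound 4 (within the scatter) because the step of a number 6.5 percentage points higher from compound 2 to compound 1 (within the scatter) on the other core stayed within the scatter. On that basis the value of compound 4 in this assay is estimated at 38%, with a likely range from 26% to 50%.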

Compound 4, a percentage reported as activity, at one dose (the size of the read-out at that dose, not a potency): 55.9%
The estimate for compound 4 lay 17.9 percentage points below the measured number; measured number outside the range, above it.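

Replacing benzyloxycarbonyl with hydrogen on a saturated chain carbon, two bonds along the chain from an amide-type nitrogen and a carbonyl carbon, gave in this assay a clear result on the core of compound 3, with a number 24.1 percentage points higher from compound 3 to compound 4 (beyond the scatter). The change therefore did not carry over with the same size from one core to the other: the same change on two cores in this assay, a number 6.5 percentage points higher (within the scatter) from compound 2 to compound 1 and a number 24.1 percentage points higher (beyond the scatter) from compound 3 to compound 4, 17.6 percentage points apart, beyond the scatter of two such steps. Going by these compounds alone, this shows that, in these two pairs, the size of the step could not be read across from one core to the other, but it does not show which feature of the cores sets the gap, nor does it give a rule for any further core, since only two pairs are available.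

The compounds shown leave open how a free carboxylic acid in place of the benzyl ester, or a longer chain in place of the methyl, would behave on each of the two cores. They also leave open whether the gap between the two steps would hold for such groups, or whether it belongs to the change from benzyloxycarbonyl to hydrogen alone.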